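Swapping nitro for methoxycarbonyl on a weak cell-growth inhibitor

A few compounds are considered here, and "the series" means these few. Any claim that something is new, unique, unknown or untested is made for them only; others in the source may bear on it.

Compound 1 `O=[N+]([O-])c1ccc(COc2ccc(OCCOCCNC3CCCC3)cc2)cc1` was tested in a functional assay on SK-OV-3 cells (Homo sapiens) for inhibition, read by CCK-8 assay, with a stated time of 70 h (a lower number here means a stronger inhibitor, a higher number a weaker inhibitor), where compound 1 gives 20300 nM. Within the data shown here, compound 2 `c1cc2c(cc1OCCOCCNC1CCCC1)CCCC2`, which carries a different aromatic core, is the only other compound measured; in this assay compound 2 gives 31900 nM. Compound 1 has the lower of the two numbers, but its gap to compound 2 lies within the scatter, so no order between the two can be claimed, and both sit in a weak range. Compound 3 `COC(=O)c1ccc(COc2ccc(OCCOCCNC3CCCC3)cc2)cc1` has not yet been measured. It differs from compound 1 in one place: methoxycarbonyl in place of nitro on an aromatic carbon. Among the measured compounds shown here, no pair of measured compounds shows what such a change does here, so there is no basis for expecting a shift in either direction. The step of a 1.2-fold higher number from compound 1 to compound 3 (0.07 log units; within the scatter) is expected to stay within the scatter. Compound 3 is expected to give 24000 nM in this assay, with a range from 8000 nM to 75000 nM.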

Compound 3, half-maximal inhibitory concentration: 6990 nM
Estimate against measurement, compound 3: 3.4-fold (0.54 log units) above, outside the stated range (below it).
By their numbers in this assay, from the lowest: compound 3; then compounds 1 and 2 (each within the scatter of the next).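

In this assay, the aromatic carbon para to a large group proves sensitive to what it carries: going from 4-nitrophenyl to 4-(methoxycarbonyl)phenyl gives a 2.9-fold lower number from compound 1 to compound 3 (0.46 log units; beyond the scatter), a modest step. Among these compounds, the earlier compounds held no pair differing in one place, so this is the first change in the set that can be read on its own, and it shows that nitro is not required at this position for inhibition in these cells. Nothing measured here accounts for the step.

As far as these compounds go, whether the lower number belongs to methoxycarbonyl itself or would also appear with a carboxylic acid, a primary amide or a nitrile at the same place remains open. Among the compounds shown here, it is also open whether the same change would have a similar effect with a longer chain in place of the one that compound 3 carries.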